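Acetyl to ethylcarbamoyl: notes toward compound 3

This account rests on a few compounds, and the source may have more. Where it says the series, first, only, none or still open, it means among the compounds named here.

Compound 1 `CC(=O)n1nc(C)c(-c2ccc(Cl)c(Cl)c2)c1N` gives 8400 nM in an assay on Sf9 cells for inhibition of mitogen-activated protein kinase kinase kinase 14 (Homo sapiens), read by ADP-Glo, with a stated time of 60 min (on this read-out lower numbers stand for stronger inhibition and higher numbers for weaker inhibition), and this is the only number shown for the series. Compound 2 `CCc1nn(C(C)=O)c(N)c1-c1ccc(Cl)c(Cl)c1` reaches only the limit > 100000 nM in this assay, which is the limit of > 100000 nM in this assay, at which 1 of the 2 values shown sits. Within the data shown here, the single measured step, an at least 11-fold higher number from compound 1 to compound 2 (1.07 log units; beyond the scatter), is therefore known only as a lower bound of its size.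

Compound 3 `CCNC(=O)n1nc(C)c(-c2ccc(Cl)c(Cl)c2)c1N` differs from compound 1 by ethylamino in place of methyl on a carbonyl carbon. Among the measured compounds shown here, the measured step from compound 1 to compound 2 concerns a different place, methyl in place of hydrogen on a saturated chain carbon bound to an aromatic carbon, and carries no information about the carbonyl carbon; no measured step bears on the change to compound 3. In the absence of a guide, the expectation for compound 3 is a step of a 1.2-fold higher number from compound 1 to compound 3 (0.08 log units; within the scatter) in this assay, that is, nothing beyond the scatter in either direction, with a correspondingly wide range. Compound 3 is thus estimated to give about 10000 nM in this assay, between 2500 nM and 40000 nM.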

Compound 3, half-maximal inhibitory concentration: > 100000 nM
Compound 3 ended at the assay's limit; the forecaster's own chance of this, stated with the estimate: 15%; at least 10-fold (1.00 log units) between middle value and limit.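

The carbonyl carbon now has a measured step of its own: an at least 11-fold higher number from compound 1 to compound 3 (1.07 log units; beyond the scatter) in this assay, for ethylamino in place of methyl. Compound 3 sits at a limit of the assay, > 100000 nM, so this change is known only as a lower bound and its true size stays unread. Acetyl on the shared core therefore does not tolerate exchange for ethylcarbamoyl in this read-out, and the carbonyl carbon joins the saturated chain carbon bound to an aromatic carbon as a second place where a single change from compound 1 ends at the limit: the limit of > 100000 nM in this assay, at which 2 of the 3 values shown sit.

Open, as far as these compounds go, is whether the step follows from the entering nitrogen with its amide hydrogen or from the longer chain; a propionyl group or a methylcarbamoyl group on the same carbonyl carbon would separate the two. Among these compounds, also open is whether any group on this carbonyl carbon, a formyl group for instance, gives a lower number than compound 1, at 8400 nM, the only number so far.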